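A few compounds are considered here, and "the series" means these few. Any claim that something is new, unique, unknown or untested is made for them only; others in the source may bear on it.

Compound 1 `CCCCCCCC(=O)Nc1ccc2[nH]cc(C3CCN(C)CC3)c2n1` gives 110 nM in an assay for binding affinity to 5-hydroxytryptamine receptor 1D (Homo sapiens), read by radioligand binding; a lower number here means a stronger inhibitor, a higher number a weaker inhibitor.
Compound 2 `CN1CCC(c2c[nH]c3ccc(NC(=O)c4cccc(F)c4)nc23)CC1` gives 690 nM.
Compound 3 `Cc1cccc(C(=O)Nc2ccc3[nH]cc(C4CCN(C)CC4)c3n2)c1` gives 490 nM.

Among these three, compound 3 stands second highest in this assay. Its nearest neighbour is compound 2, and the step of a 1.4-fold lower number from compound 2 to compound 3 (0.15 log units; within the scatter) lies within the scatter, so the two cannot be told apart. Its furthest neighbour is compound 1, and the step of a 4.5-fold higher number from compound 1 to compound 3 (0.65 log units; beyond the scatter) is beyond the scatter.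

Compound 4 `CN1CCC(c2c[nH]c3ccc(NC(=O)c4ccc(C#N)cc4)nc23)CC1` has not yet been measured. It differs from compound 3 in one place: 4-cyanophenyl in place of 3-methylphenyl on a carbonyl carbon. Going by the values given here, two measured steps bear on this. The steps of a 6.3-fold higher number from compound 1 to compound 2 (0.80 log units; beyond the scatter) and a 4.5-fold higher number from compound 1 to compound 3 (0.65 log units; beyond the scatter) show that replacing heptyl with either aryl group raised the number modestly. The step of a 1.4-fold lower number from compound 2 to compound 3 (0.15 log units; within the scatter) shows that exchanging one small group on the aryl ring for another stayed within the scatter. Since compound 4 keeps an aryl group on the carbonyl carbon and only the group on that ring changes, the expected step of a 1.2-fold higher number from compound 3 to compound 4 (0.09 log units; within the scatter) is small, and compound 4 is estimated at 600 nM, within the range 250 nM to 1500 nM.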

Compound 4, inhibition constant: 380 nM
The estimate for compound 4 lay 1.6-fold (0.20 log units) above the measured number; measured number inside the range.
By their numbers in this assay, from the lowest: compound 1; then compounds 4, 3 and 2 (each within the scatter of the next).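

In this assay, 4-cyanophenyl differs from the earlier aryl groups in both its ring substituent and that substituent's numbered position, yet the steps of a 1.3-fold lower number from compound 3 to compound 4 (0.11 log units; within the scatter) and a 1.8-fold lower number from compound 2 to compound 4 (0.26 log units; within the scatter) leave compounds 2, 3 and 4 impossible to tell apart. Heptyl remains the group that stands out on this carbonyl carbon: the step of a 3.5-fold higher number from compound 1 to compound 4 (0.54 log units; beyond the scatter) shows that the gap seen with the two earlier aryl groups also holds for a third, leaving compound 1 the strongest binder of the four. No measurement shown here offers an explanation for these results.

The compounds shown leave open how a shorter chain, such as butyl, or a longer chain, such as decyl, would compare with heptyl. They also leave open whether cyclohexyl, a saturated ring, would track heptyl or the aryl groups.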